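The source may report more compounds than this note shows. Statements on the series, on what has been measured and on what is new or still open speak of the compounds shown alone.

Measured compounds:
compound 1 `Nc1nc(-c2ccc(C3CC3)o2)nc2sc(Cc3ccccc3)cc12` — 861 nM
compound 2 `Nc1nc(-c2ccc(C(F)F)o2)nc2sc(Cc3ccccc3)cc12` — 3000 nM
compound 3 `Nc1nc(-c2cnco2)nc2sc(Cc3ccccc3)cc12` — 106 nM

All three were run in a functional assay on CHO-K1 cells for antagonist activity at adenosine receptor A1 (Homo sapiens), read by a beta-galactosidase reporter and cAMP accumulation, with stated times of 15 min and 6 h; on this read-out higher numbers stand for weaker inhibition and lower numbers for stronger inhibition. Compound 3 stands lowest of the three numbers: the step of an 8.1-fold lower number from compound 1 to compound 3 (0.91 log units; beyond the scatter) is beyond the scatter, and the step of a 28-fold lower number from compound 2 to compound 3 (1.45 log units; beyond the scatter) is larger still. Within the furan pair, the step of a 3.5-fold higher number from compound 1 to compound 2 (0.54 log units; beyond the scatter) is also beyond the scatter, so the group on this position of the shared core of compound 3 clearly moves the read-out.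

Compound 4 `Cc1csc(-c2nc(N)c3cc(Cc4ccccc4)sc3n2)n1` differs from compound 3 by 4-methyl-1,3-thiazol-2-yl in place of 1,3-oxazol-5-yl on an aromatic carbon. Going by the values given here, no measured step swaps one small heteroaryl for another of the same kind at this position; the steps on record swap a substituted furan for the oxazole, or change the substituent on the furan. They show only that the heteroaryl here matters and that compound 3 sits at the favourable end of what has been seen. Since every other variant at this position gave a higher number than compound 3, a modest rise is expected for compound 4, though a number within the scatter of compound 3 cannot be excluded. This corresponds to an expected step of a 2.4-fold higher number from compound 3 to compound 4 (0.37 log units; beyond the scatter). Compound 4 is therefore estimated at 250 nM, with a range from 80 nM to 800 nM.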

Compound 4, inhibition constant: 1490 nM
Compound 4: middle estimate off by 6.0-fold (0.78 log units), on the low side; the whole stated range lies below it.
By their numbers in this assay, from the lowest: compound 3; then compounds 1, 4 and 2 (each within the scatter of the next, the first and the last beyond it).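

Both the leaving 1,3-oxazol-5-yl and the entering 4-methyl-1,3-thiazol-2-yl are five-membered aromatic rings with 2 hetero atoms and the same counted hydrogen-bond donors and acceptors, yet in this assay the step is a 14-fold higher number from compound 3 to compound 4 (1.15 log units; beyond the scatter), so these shared features do not by themselves keep the number low. The other two steps, a 2.0-fold lower number from compound 2 to compound 4 (0.30 log units; within the scatter) and a 1.7-fold higher number from compound 1 to compound 4 (0.24 log units; within the scatter), place compound 4 level with each of the substituted furans, so compound 3 alone stands apart among the four compounds, although compounds 1 and 2 still differ from each other beyond the scatter. No supporting data on hand bear on the origin of the gap between compound 3 and compound 4.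

The change from compound 3 to compound 4 alters the ring atoms, the point of attachment and the methyl group in a single step, so the share of each in the rise cannot be separated. As far as these compounds go, what a plain 1,3-thiazol-2-yl or a 4-methyl-1,3-oxazol-2-yl group would give at this position on the shared core remains open, and either would help divide that step.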